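Methoxy Replaces Fluoro on a Shared Two-Ring Core

The source may hold more compounds than are shown below. What is called first, only, known or untested is meant among the compounds shown, and "the series" means these compounds.

Measured compounds:
compound 1, `Cc1ccc2nc(Nc3nc(Nc4ccc(S(N)(=O)=O)cc4)ncc3C)sc2c1`, 2710 nM
compound 2, `Cc1cnc(Nc2ccc(S(N)(=O)=O)cc2)nc1Nc1nc2ccc(F)cc2s1`, 6980 nM

In a functional assay on PC-3 cells (Homo sapiens) for antiproliferative activity, read by MTT assay, with a stated time of 48 h (on this read-out lower numbers stand for stronger inhibition and higher numbers for weaker inhibition), compound 1 gives 2710 nM. Going by the values given here, compound 2 gives 6980 nM in this assay, which is the higher, and therefore weaker, of the two numbers seen so far; the only step measured is a 2.6-fold higher number from compound 1 to compound 2 (0.41 log units; beyond the scatter). Compound 3, `COc1ccc2nc(Nc3nc(Nc4ccc(S(N)(=O)=O)cc4)ncc3C)sc2c1`, is the next member and differs from compound 2 in one place: methoxy in place of fluoro on an aromatic carbon.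

Among the compounds with values here, no measured step exchanges fluoro for methoxy, so the expectation rests on the single step from methyl to fluoro, which was modest and went toward a weaker compound. Methoxy, like methyl, carries a carbon at this position, so the number for compound 3 is expected to fall somewhat, back toward the region of compound 1, though the change is not the same as reversing the measured step and wide uncertainty remains. Compound 3 is expected to give about 4000 nM in this assay, within a range from 1500 nM to 11000 nM. This estimate corresponds to an expected step of a 1.7-fold lower number from compound 2 to compound 3 (0.24 log units; within the scatter).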

Compound 3, half-maximal inhibitory concentration: > 50000 nM
Compound 3: only a limit was reported; the forecaster's own chance of this, stated with the estimate: 5%; middle value at least 12-fold (1.09 log units) from the limit.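

Compound 1 and compound 2 showed only that methyl and fluoro on this aromatic carbon are separated by a modest step, which left it possible that small changes here matter little. In this assay compound 3 gives > 50000 nM, a limit of the assay and not a number. Methoxy is therefore the first group here to weaken the compound strongly, with an at least 7.1-fold higher number from compound 2 to compound 3 (0.85 log units; beyond the scatter) and an at least 18-fold higher number from compound 1 to compound 3 (1.26 log units; beyond the scatter), so this position is far less forgiving than the first pair suggested, and both steps give only their smallest possible size: the limit of > 50000 nM in this assay, at which 1 of the 3 values shown sits.

Methoxy differs from fluoro in two counted ways, with two heavy atoms in place of one and one hydrogen-bond acceptor in place of none, and these three compounds cannot separate the two. An ethyl group, which has the same heavy-atom count without the oxygen, or a hydroxyl group, which keeps the oxygen on a single heavy atom, would be the comparisons that show whether the size of the group or its oxygen goes with the weakening.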